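Shifting the chlorine on the amine-linked phenyl ring

A few compounds are considered here, and "the series" means these few. Any claim that something is new, unique, unknown or untested is made for them only; others in the source may bear on it.

Compound 2, `FC(F)(F)c1ccc(CSc2nc(Nc3ccccc3Cl)c3ccccc3n2)cc1`, gives 20400 nM in a functional assay on PC-3 cells (Homo sapiens) for cytotoxicity, read by MTT assay, with a stated time of 72 h; on this read-out lower numbers stand for stronger inhibition and higher numbers for weaker inhibition. Of the two compounds with a number in this assay, compound 2 stands highest. Compound 3, `FC(F)(F)c1ccc(CSc2nc(Nc3cccc(Br)c3)c3ccccc3n2)cc1`, gives 8680 nM. Compound 1, `CCCCCCCCCCCCCCNc1nc(SCc2ccc(C(F)(F)F)cc2)nc2ccccc12`, reaches only the limit of this assay, > 50000 nM. Within the data shown here, the single measured step between these compounds, a 2.4-fold lower number from compound 2 to compound 3 (0.37 log units; beyond the scatter), comes from putting 3-bromophenyl in place of 2-chlorophenyl on the nitrogen on the aromatic ring.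

Compound 4, `FC(F)(F)c1ccc(CSc2nc(Nc3ccc(Cl)cc3)c3ccccc3n2)cc1`, is not yet measured. It differs from compound 2 by 4-chlorophenyl in place of 2-chlorophenyl on a nitrogen on an aromatic ring. This resembles the measured step in that the 2-chlorophenyl leaves and another halogen-bearing phenyl ring enters, though the halogen and its name differ. Among the measured compounds shown here, only that one step bears on the change; it was modest and beyond the scatter, so a lowering of similar size is expected, a 2.3-fold lower number from compound 2 to compound 4 (0.36 log units; beyond the scatter). Compound 4 is therefore estimated at 9000 nM, with an expected range from 3000 nM to 30000 nM, kept wide because compound 3 alone, through a 2.4-fold lower number from compound 2 to compound 3 (0.37 log units; beyond the scatter), supports the expectation.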

Compound 4, half-maximal inhibitory concentration: 7110 nM
Compound 4: middle estimate off by 1.3-fold (0.10 log units), on the high side; low and high end bracket the measured number.
By their numbers in this assay, from the lowest: compounds 4 and 3 (each within the scatter of the next); then compound 2. At a limit, above all of these: compound 1.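

Moving the chlorine alone, from 2-chlorophenyl to 4-chlorophenyl with the same atoms joined differently, gives a 2.9-fold lower number from compound 2 to compound 4 (0.46 log units; beyond the scatter) in this assay. This shows that where the halogen sits on this ring matters in its own right, which the earlier step could not show, since it changed the halogen and its place together. The step from 3-bromophenyl to 4-chlorophenyl, a 1.2-fold lower number from compound 3 to compound 4 (0.09 log units; within the scatter), puts these two compounds level, so in this small set the 2-chlorophenyl ring stands apart from both.

Nothing given here explains why the place of the halogen makes this difference. Still open, as far as these compounds go, is how a phenyl ring with no halogen at all, or one carrying an amine or a carboxylic acid instead, would behave at this nitrogen.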